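This account rests on a few compounds, and the source may have more. Where it says the series, first, only, none or still open, it means among the compounds named here.

Of the compounds shown here, three share one core and have been measured in a functional assay on HCT-116 cells (Homo sapiens) for inhibition, read by sulforhodamine B assay, with a stated time of 72 h; a higher number here means a weaker inhibitor, a lower number a stronger inhibitor. Compound 1 `CC(c1ccc(-c2ccccc2)c(F)c1)c1nnc2n1N=C(c1ccccc1)CS2` gives 9700 nM in this assay. Going by the values given here, compound 3 `COc1ccc(C2=Nn3c(nnc3C(C)c3ccc(-c4ccccc4)c(F)c3)SC2)cc1`, which carries a methoxy in place of hydrogen on an aromatic carbon, gives 4400 nM in this assay, and the step of a 2.2-fold lower number from compound 1 to compound 3 (0.34 log units; beyond the scatter) is the only single-point comparison available among the measured set. Compound 2 `CC(C)Cc1ccc(C(C)c2nnc3n2N=C(c2ccc(Br)cc2)CS3)cc1` gives 7100 nM in this assay; its number sits within the scatter of both compound 1 and compound 3, so no ordering of compound 2 against either of them can be read from these figures.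

Compound 4 `CC(C)Cc1ccc(C(C)c2nnc3n2N=C(c2ccc(F)cc2)CS3)cc1` has not yet been measured. It differs from compound 2 by fluoro in place of bromo on an aromatic carbon. Among the compounds with values here, none of the measured steps concerns this part of the molecule: the one recorded step, from compound 1 to compound 3, changes a different aromatic carbon and a different group, so it offers no guide to the size or direction of a bromo-to-fluoro exchange here. With no bearing evidence, the step from compound 2 to compound 4 is expected to stay within the scatter, a 1.1-fold higher number from compound 2 to compound 4 (0.02 log units; within the scatter). Compound 4 is therefore estimated at 7500 nM in this assay, with a range from 3500 nM to 16000 nM.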

Compound 4, half-maximal inhibitory concentration: 12400 nM
Compound 4: middle estimate off by 1.7-fold (0.22 log units), on the low side; the range from low to high includes it.
By their numbers in this assay, from the lowest: compounds 3, 2, 1 and 4 (each within the scatter of the next, the first and the last beyond it).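

At this place on the shared core, para to a large group, exchanging 4-bromophenyl for 4-fluorophenyl gives a 1.7-fold higher number from compound 2 to compound 4 (0.24 log units; within the scatter) in this assay, so the two halogens cannot be told apart here. Going by these compounds alone, this is the first reading of one halogen in place of another; the only earlier step, a 2.2-fold lower number from compound 1 to compound 3 (0.34 log units; beyond the scatter), put methoxy in place of hydrogen and so said nothing about such an exchange. No measurement is available that would explain the result, and it rests on this single pair.

The compounds shown leave open whether a group of another kind on this ring, such as an amine, a carboxylic acid or a longer alkoxy chain, would move the number beyond the scatter, since only bromo and fluoro are compared directly here. They also leave open whether the same exchange of bromo for fluoro would stay within the scatter on the fluorinated biphenyl side chain of compound 1 and compound 3, rather than on the side chain that compound 2 and compound 4 share.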